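This account rests on a few compounds, and the source may have more. Where it says the series, first, only, none or still open, it means among the compounds named here.

Measured compounds:
compound 1 `C=C(CC)C(=O)c1ccc(OCC(=O)Nc2cccc(C(=O)O)c2)c(Cl)c1Cl`: 20600 nM
compound 2 `C=C(CC)C(=O)c1ccc(OCC(=O)Nc2ccc(Cl)c(C(=O)O)c2)c(Cl)c1Cl`: 15900 nM
compound 3 `C=C(CC)C(=O)c1ccc(OCC(=O)NCC2CCC(C(=O)O)CC2)c(Cl)c1Cl`: 8000 nM

In a functional assay on CLL cells (Homo sapiens) for cytotoxicity, read by MTT assay, with a stated time of 48 h (a higher number here means that more compound is needed for the effect, a lower number that less compound is needed), compound 1 stands at the highest of the three numbers. Compound 2 lies nearest to it, and the step of a 1.3-fold lower number from compound 1 to compound 2 (0.11 log units; within the scatter) is within the scatter. For the measured compounds named here, compound 3 lies furthest from compound 1; the two values show a gap beyond the scatter, with compound 3 at the lower number, but no single-point step joins these two compounds.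

Compound 4 `C=C(CC)C(=O)c1ccc(OCC(=O)Nc2ccc(O)cc2)c(Cl)c1Cl` differs from compound 1 in one place: 4-hydroxyphenyl in place of 3-carboxyphenyl on an amide-type nitrogen. Going by the values given here, none of the measured steps covers a change of this kind. The only step shown, from compound 1 to compound 2, concerns chloro in place of hydrogen on an aromatic carbon and is within the scatter, so it gives no guidance on exchanging one aryl group for another on the amide-type nitrogen. Among the compounds with values here, with no comparable step in the set, no step beyond the scatter is expected in this assay in either direction. Compound 4 is therefore estimated at 14000 nM, with a range from 5000 nM to 40000 nM. The expected step of a 1.5-fold lower number from compound 1 to compound 4 (0.17 log units; within the scatter) is small.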

Compound 4, half-maximal effective concentration: 6400 nM
Estimate against measurement, compound 4: 2.2-fold (0.34 log units) above; the range from low to high includes it.
By their numbers in this assay, from the lowest: compounds 4, 3, 2 and 1 (each within the scatter of the next, the first and the last beyond it).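

For the compounds shown here, the amide-type nitrogen turns out to be a place where exchanging the aryl group can shift the number in this assay: 4-hydroxyphenyl in place of 3-carboxyphenyl gives a 3.2-fold lower number from compound 1 to compound 4 (0.51 log units; beyond the scatter), whereas the only earlier single-place step, a 1.3-fold lower number from compound 1 to compound 2 (0.11 log units; within the scatter), was a chloro exchange on an aromatic carbon and stayed within the scatter. Compound 4 also shows that 3-carboxyphenyl on this nitrogen is not required for the effect in this assay. No measurement given here accounts for the step.

This one change removes 3-carboxyphenyl and brings in 4-hydroxyphenyl together, and the compounds shown do not separate the two. Plain phenyl, 3-hydroxyphenyl or 4-carboxyphenyl on the same nitrogen would speak to that, and an amine on the aryl ring remains an open question.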